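Hydroxymethyl for Ethyl on a Shared Boron-Bearing Core

This account rests on a few compounds, and the source may have more. Where it says the series, first, only, none or still open, it means among the compounds named here.

Compound 1 `O=C(c1ccn(-c2ccc3c(c2)B(O)OC3)c1)c1ccc(Cl)cc1Cl`: in an ADME assay on L929 cells (Mus musculus) for cytotoxicity, read by resazurin assay, with a stated time of 72 h (on this read-out lower numbers stand for stronger inhibition and higher numbers for weaker inhibition), compound 1 reaches only the limit > 10 ug/mL.
Compound 2 `O=C(c1ccccc1)c1ccn(-c2ccc3c(c2)B(O)OC3)c1`: in this assay compound 2 reaches only the limit > 10 ug/mL.
Compound 3 `CCc1ccc(C(=O)c2ccn(-c3ccc4c(c3)B(O)OC4)c2)cc1`: in this assay compound 3 reaches only the limit > 10 ug/mL.

All three measured compounds share the same core and differ only in the aromatic group attached to the carbonyl carbon. None of them gives a number; each stops at a limit of the assay, and compound 3 stands at that limit like the other two, as the limit of > 10 ug/mL in this assay, at which 3 of the 3 values shown sit, shows.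

Compound 4 `O=C(c1ccc(CO)cc1)c1ccn(-c2ccc3c(c2)B(O)OC3)c1` differs from compound 3 by hydroxy in place of methyl on a saturated chain carbon bound to an aromatic carbon. For the measured compounds named here, three measured steps touch the same region of the molecule, yet none of them can be read: a step that the two limits leave unreadable from compound 1 to compound 2, a step that the two limits leave unreadable from compound 1 to compound 3 and a step that the two limits leave unreadable from compound 2 to compound 3. So the measured steps give no direction and no size for the change from compound 3 to compound 4.

With nothing readable to lean on, compound 4 is expected to sit where the others sit, with a step that the limit leaves unreadable from compound 3 to compound 4 expected to be no step beyond the scatter. The estimate for compound 4 in this assay is 20 ug/mL, with a range from 8 ug/mL to 60 ug/mL, and most likely the assay will again report only a limit.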

Compound 4, half-maximal inhibitory concentration: 9.31 ug/mL
Beside the measured number, compound 4's estimate is 2.1-fold (0.33 log units) above it, and the stated range covers the measured number.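

Compound 4 alone among the four gives a number in this assay, 9.31 ug/mL, so a hydroxymethyl group on this phenyl ring is the one change shown that brings a reading inside the assay's range. The other three compounds stop at a limit of the assay: the limit of > 10 ug/mL in this assay, at which 3 of the 4 values shown sit. Swapping ethyl for hydroxymethyl gives an at least 1.0-fold lower number from compound 3 to compound 4 (0.03 log units; that floor lies within the scatter), adding hydroxymethyl to the plain phenyl gives an at least 1.0-fold lower number from compound 2 to compound 4 (0.03 log units; that floor lies within the scatter), and replacing 2,4-dichlorophenyl gives an at least 1.0-fold lower number from compound 1 to compound 4 (0.03 log units; that floor lies within the scatter); each is only a floor, and the steps among the other three compounds cannot be read.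

From the compounds shown here alone, the true size of these steps therefore stays open, and the change may be no more than scatter. Also open, going by these compounds, is how the number would respond to a carboxylic acid, an amine or a longer hydroxyalkyl chain in place of hydroxymethyl.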